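Isobutyl to isopropyl swap, carried across a second core

A few compounds are considered here, and "the series" means these few. Any claim that something is new, unique, unknown or untested is made for them only; others in the source may bear on it.

Compound 1 `CC(C)[C@H](NC(=S)Nc1ccccc1)c1nc2ccccc2[nH]1` and compound 2 `CC(C)C[C@H](NC(=S)Nc1ccccc1)c1nc2ccccc2[nH]1` share a core and differ only at the saturated chain carbon bound to an amide-type nitrogen and an aromatic carbon. In a functional assay on HeLa cells (Homo sapiens) for cytotoxicity, read by MTT assay (a higher number here means a weaker inhibitor, a lower number a stronger inhibitor), compound 2 gives 29100 nM and compound 1 gives 11100 nM; the change isopropyl in place of isobutyl on a saturated chain carbon bound to an amide-type nitrogen and an aromatic carbon made a 2.6-fold lower number from compound 2 to compound 1 (0.42 log units; beyond the scatter). Compound 3 `CC(C)C[C@@H](NC(=S)Nc1cc(C(F)(F)F)cc(C(F)(F)F)c1)c1nc2ccccc2[nH]1` carries a different core, and in this assay compound 3 gives 10400 nM; the difference between its core and that of compound 2 is not broken down here, and its value sits within the scatter of that of compound 1. Compound 4 `CC(C)[C@@H](NC(=S)Nc1cc(C(F)(F)F)cc(C(F)(F)F)c1)c1nc2ccccc2[nH]1` is not yet measured. It differs from compound 3 by isopropyl in place of isobutyl on a saturated chain carbon bound to an amide-type nitrogen and an aromatic carbon, the same change that was made from compound 2 to compound 1, at a place described in the same words. For compound 4 the expected step in this assay is a 2.1-fold lower number from compound 3 to compound 4 (0.32 log units; beyond the scatter), set beside a 2.6-fold lower number from compound 2 to compound 1 (0.42 log units; beyond the scatter); it rests on that one measured pair alone, so it is held loosely. For compound 4 in this assay the estimate is 5000 nM, with a range from 2000 nM to 12000 nM.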

Compound 4, half-maximal inhibitory concentration: 16200 nM
Beside the measured number, compound 4's estimate is 3.2-fold (0.51 log units) below it; measured number outside the range, above it.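

In this assay the change of isobutyl to isopropyl does not carry over as one fixed step from one core to the other: the same change on two cores in this assay, a 2.6-fold lower number (0.42 log units; beyond the scatter) from compound 2 to compound 1 and a 1.6-fold higher number (0.19 log units; within the scatter) from compound 3 to compound 4, 4.1-fold (0.61 log units) apart, beyond the scatter of two such steps

On the second core the change gives a 1.6-fold higher number from compound 3 to compound 4 (0.19 log units; within the scatter), so no real shift can be claimed there, while the lower number on the first core stands as measured. With a single pair on each core, this does not show which feature of the cores goes with the gap, nor how the change would behave on any further core.

The compounds shown leave open how the number responds at the saturated chain carbon bound to an amide-type nitrogen and an aromatic carbon to groups other than these two, such as cyclopropyl, a longer chain or benzyl. Also open, from the compounds shown here alone, is whether the gap between the two steps follows the pair of trifluoromethyl groups, which a core carrying a single trifluoromethyl group or chlorine could test.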